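The source may hold more compounds than are shown below. What is called first, only, known or untested is meant among the compounds shown, and "the series" means these compounds.

In an assay on NK92 cells for inhibition of interleukin-2 (Homo sapiens), read by AlphaScreen, with stated times of 30 min and 1 h (on this read-out higher numbers stand for weaker inhibition and lower numbers for stronger inhibition), compound 1 `CCOC(CCn1c(Cc2nn(C)c(=O)c3ccccc23)nnc1SCCCCCCCC(=O)Nc1ccc(Cl)cc1Cl)OCC` gives only a limit, > 30000 nM. Compound 2 `Cn1c(Cc2nn(CCC=O)c(=O)c3ccccc23)nnc1SCC(=O)Nc1ccc(Cl)cc1Cl` likewise returns only a limit, > 30000 nM. Compound 3 `Cn1c(Cc2nn(CCCO[Si](C)(C)C(C)(C)C)c(=O)c3ccccc23)nnc1SCCCCCCCC(=O)Nc1ccc(Cl)cc1Cl` also reaches only a limit, > 30000 nM. Going by the values given here, all three measured compounds thus sit at the limit of > 30000 nM in this assay, at which 3 of the 3 values shown sit, and none of them carries a number that could be set against another, so compound 3 stands at the same limit as its two companions, with no measured step between any pair.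

Compound 4 `Cn1c(Cc2nn(CCC(=O)O)c(=O)c3ccccc23)nnc1SCCCCCCCC(=O)Nc1ccc(Cl)cc1Cl` differs from compound 3 by a group of 3 heavy atoms (1 carbon, 2 oxygen; no ring) in place of a group of 9 heavy atoms (7 carbon, 1 oxygen, 1 silicon; no ring), on a saturated chain carbon, two bonds along the chain from an aromatic nitrogen, a carboxy taking the place of the larger group on a saturated chain carbon, two bonds along the chain from an aromatic nitrogen. Among the compounds with values here, every value so far is a limit, and the numbers show neither a direction nor a size for any step. Compound 4 is therefore expected to give a limit again in this assay. The expected change is a step that the limit leaves unreadable from compound 3 to compound 4. The estimate for compound 4 is 40000 nM, within a range from 8000 nM to 200000 nM.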

Compound 4, half-maximal inhibitory concentration: 30000 nM
Compound 4: the middle estimate sits 1.3-fold (0.12 log units) above what was measured; measured number inside the range.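

Going by these compounds alone, compound 4 is the only one of the four compounds with a plain number rather than a limit, giving 30000 nM in this assay. On a saturated chain carbon, two bonds along the chain from an aromatic nitrogen, carboxy in place of the larger silicon-bearing group gives a number no higher, read as a number no higher from compound 3 to compound 4 (the limit leaves the size open). This shows only that carboxy at this place does not push the value past the top of the measurable range, and the size of the step cannot be read: the limit of > 30000 nM in this assay, at which 3 of the 4 values shown sit.

The compounds shown cannot tell whether carboxy itself matters or whether losing the larger group is enough. An amine or a hydroxyl at this place, or a longer chain carrying the carboxy, would be needed to show whether any group here can bring the number clearly lower.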